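Fluorine placement on the pendant aryl group of compound 2

This account rests on a few compounds, and the source may have more. Where it says the series, first, only, none or still open, it means among the compounds named here.

The three measured compounds share one core and differ in the aryl group attached to it and in the end of the benzylamide: compound 1 `Cn1cc(-c2cc(C(C)(C)O)ccc2Oc2ccc(F)cc2F)c2cc(C(=O)NCc3ccc(C(=O)Nc4ccccc4N)cc3)[nH]c2c1=O`, compound 2 `Cn1cc(-c2ccccc2F)c2cc(C(=O)NCc3ccc(C(=O)Nc4ccccc4N)cc3)[nH]c2c1=O` and compound 3 `CC(C)Oc1ccc(C(C)(C)O)cc1-c1cn(C)c(=O)c2[nH]c(C(=O)NCc3ccc(C(=O)NO)cc3)cc12`. In a functional assay on MV4-11 cells (Homo sapiens) for antiproliferative activity, read by CCK-8 assay, with a stated time of 72 h (on this read-out higher numbers stand for weaker inhibition and lower numbers for stronger inhibition), compound 1 gives 90 nM, compound 2 gives 230 nM and compound 3 gives 350 nM. Compound 2 thus holds the second highest of the three numbers; its nearest neighbour is compound 3, whose number lies within the scatter of that of compound 2, while compound 1 stands furthest away, with a number lower than that of compound 2 by a gap beyond the scatter.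

Compound 4 `Cn1cc(-c2cccc(F)c2)c2cc(C(=O)NCc3ccc(C(=O)Nc4ccccc4N)cc3)[nH]c2c1=O` keeps the core and the benzylamide of compound 2 and differs only in the aryl group: 3-fluorophenyl in place of 2-fluorophenyl on an aromatic carbon. Going by the values given here, no measured pair in this set shows such a change, so neither direction nor size can be read from the numbers at hand. The expected step in this assay is a 1.0-fold lower number from compound 2 to compound 4 (0.02 log units; within the scatter), which amounts to no change beyond the scatter. The number expected for compound 4 in this assay is 220 nM, with a range from 90 nM to 550 nM.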

Compound 4, half-maximal inhibitory concentration: 210 nM
Estimate against measurement, compound 4: 1.0-fold (0.02 log units) above, and the stated range covers the measured number.
By their numbers in this assay, from the lowest: compound 1; then compounds 4, 2 and 3 (each within the scatter of the next).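

In this assay, going by these compounds alone, 3-fluorophenyl in place of 2-fluorophenyl on this aromatic carbon of the shared core gives a 1.1-fold lower number from compound 2 to compound 4 (0.04 log units; within the scatter), and this is the first pair that differs in one place only. The earlier compounds shown here gave no reading of any single change; this pair shows that, for these two fluorophenyl isomers, the location of the fluorine on the pendant ring does not separate the compounds in this cell read-out. Nothing at hand explains this result, and the finding rests on a single pair in a single assay.

Going by these compounds, whether the fluorine contributes at all remains open, since the pair says nothing about how a plain phenyl group would compare with either fluorophenyl group. Also open, on these data alone, is how far this position accepts other substituents on the pendant ring, such as an amine, a carboxylic acid or a longer alkoxy chain, and whether the same indifference to fluorine placement would hold with the hydroxamic acid end of compound 3.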